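Bromo in place of cyano: working notes

This account rests on a few compounds, and the source may have more. Where it says the series, first, only, none or still open, it means among the compounds named here.

Measured in an ADME assay on microsomes from liver (Homo sapiens) for metabolic stability, with a stated time of 10 min; on this read-out higher numbers stand for a more stable compound and lower numbers for a less stable compound:
- compound 1 `FC(F)(F)c1ccccc1-c1ccc2[nH]c(C3=NOC4(CCCCC4)C3)nc2c1`: 100%
- compound 2 `FC(F)(F)c1ccccc1-c1cc(Cl)c2[nH]c(C3=NOC4(CCCCC4)C3)nc2c1`: 92%
- compound 3 `N#Cc1cc(-c2ccccc2C(F)(F)F)cc2nc(C3=NOC4(CCCCC4)C3)[nH]c12`: 68%

Compound 3, at 68%, is the lowest of the three, beyond the scatter from both others. The next analogue, compound 4 `FC(F)(F)c1ccccc1-c1cc(Br)c2[nH]c(C3=NOC4(CCCCC4)C3)nc2c1`, is not yet measured. The change to it is bromo in place of cyano on an aromatic carbon, ortho to a fused ring.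

For the measured compounds named here, three measured steps bear on this. The chloro step, a number 8 percentage points lower from compound 1 to compound 2 (within the scatter), stays within the scatter. The cyano steps are larger: a number 32 percentage points lower from compound 1 to compound 3 (beyond the scatter), and a number 24 percentage points lower from compound 2 to compound 3 (beyond the scatter). Going by the values given here, no bromo compound has been measured, so chloro is the nearest guide, and compound 2 at 92% sets the expected level. A modest rise beyond the scatter is therefore expected, roughly reversing the step from chloro to cyano. The expected size is a number 20 percentage points higher from compound 3 to compound 4 (beyond the scatter). Compound 4 is estimated at 88%, with an expected range of 74% to 100%.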

Compound 4, percent of the compound remaining: 100%
Compound 4: middle estimate off by 12 percentage points, on the low side, within the range that was stated.
By their numbers in this assay, from the lowest: compound 3; then compounds 2, 1 and 4 (each within the scatter of the next).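

In this assay, bromo at this position, ortho to a fused ring, reads the same as the other non-nitrile compounds: a number 8 percentage points higher from compound 2 to compound 4 (within the scatter), and no change at the digits printed from compound 1 to compound 4 (within the scatter). Replacing the nitrile with bromo gives a number 32 percentage points higher from compound 3 to compound 4 (beyond the scatter), so compound 3 alone stands apart among the four compounds, and neither halogen shows a step beyond the scatter from hydrogen. Nothing available here accounts for the separation of the nitrile from the halogens.

Going by these compounds, whether an amine, a carboxylic acid or a methoxy group at this position would read with the halogens or with the nitrile remains open. Compound 1, compound 2 and compound 4 all lie within the scatter of one another, so no ranking among hydrogen, chloro and bromo can be drawn.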